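Notes on the step from compound 1 to compound 3

The source may hold more compounds than are shown below. What is called first, only, known or untested is meant among the compounds shown, and "the series" means these compounds.

Measured in a functional assay on HT-29 cells (Homo sapiens) for cytotoxicity, read by MTT assay, with a stated time of 72 h; on this read-out higher numbers stand for weaker inhibition and lower numbers for stronger inhibition:
- compound 1, `CN(C)CCn1cnnc1-c1cc(Oc2ccc(NC(=O)N/N=C/c3ccc(Cl)cc3Cl)cc2F)ccn1`, gives 390 nM
- compound 2, `CN(C)CCn1cnnc1-c1cc(Oc2ccc(NC(=O)N/N=C/c3ccc(O)c(Br)c3)cc2F)ccn1`, gives 450 nM

Compound 1 stands at the lowest of the two numbers in this assay; its nearest neighbour is compound 2, and the step of a 1.2-fold higher number from compound 1 to compound 2 (0.06 log units; within the scatter) does not separate the two.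

Compound 3, `CN(C)CCn1cnnc1-c1cc(Oc2ccc(NC(=O)N/N=C/c3cc(Br)c(O)c(Br)c3)cc2F)ccn1`, is not yet measured. It differs from compound 1 as follows: 3,5-dibromo-4-hydroxyphenyl in place of 2,4-dichlorophenyl on a carbon with a double bond to nitrogen

For the measured compounds named here, the only measured step that bears on this change is a 1.2-fold higher number from compound 1 to compound 2 (0.06 log units; within the scatter), where 3-bromo-4-hydroxyphenyl in place of 2,4-dichlorophenyl on a carbon with a double bond to nitrogen left the number within the scatter. Going by the values given here, compound 3 carries 3,5-dibromo-4-hydroxyphenyl instead; no measured pair isolates the second bromine, so nothing measured argues for a shift in either direction beyond what compound 2 already showed. The expectation for compound 3 in this assay is therefore a step of a 1.2-fold higher number from compound 1 to compound 3 (0.06 log units; within the scatter), that is, none beyond the scatter.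

Compound 3 is expected to give about 450 nM, within a range from 180 nM to 1100 nM.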

Compound 3, half-maximal inhibitory concentration: 2670 nM
Compound 3: the middle estimate sits 5.9-fold (0.77 log units) below what was measured; the measured number lies above the stated range.
By their numbers in this assay, from the lowest: compounds 1 and 2 (each within the scatter of the next); then compound 3.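

In this assay the aryl group on a carbon with a double bond to nitrogen is shown for the first time to move the number beyond the scatter: 3,5-dibromo-4-hydroxyphenyl in place of 2,4-dichlorophenyl gives a 6.8-fold higher number from compound 1 to compound 3 (0.84 log units; beyond the scatter) and so separates itself from the earlier swap, which stayed within the scatter. For the compounds shown here, the single change of bromo in place of hydrogen on an aromatic carbon gives a 5.9-fold higher number from compound 2 to compound 3 (0.77 log units; beyond the scatter) in this one pair, so weaker inhibition here goes with the added bromo rather than with the hydroxy-bearing ring as such, since compound 2 also carries the hydroxy group. Nothing available explains why this one added bromo produces a step of this size.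

The compounds shown leave open whether the step is tied to bromine itself or would also appear with a smaller or different substituent, as in 3,5-dichloro-4-hydroxyphenyl or 3,5-dimethyl-4-hydroxyphenyl. They also leave open what the hydroxy group contributes to this step, a question that a methoxy group in its place, on the same dibromophenyl ring, would address.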